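The compounds below may be only part of what the source reports. "The series", "measured", "known", "first", "only" and "open" are said of these compounds alone.

Measured so far in an assay on a protein complex for displacement of a labelled ligand from CDK8/Cyclin C (Homo sapiens), read by TR-FRET, with a stated time of 1 h; a lower number here means a stronger inhibitor, a higher number a weaker inhibitor:

compound 1 `Nc1nccc(N2CC[C@H](NC(=O)Nc3ccc(Cl)c(C(F)(F)F)c3)C2)n1`: 42.3 nM
compound 2 `CNc1nccc(N2CC[C@H](NC(=O)Nc3ccc(OC)cc3)C2)n1`: 7160 nM

Compound 1 holds the lowest of the two numbers. Compound 2 gives a far higher number, and the gap between the two lies beyond the usual scatter. Among the compounds with values here, compound 2 differs from compound 1 in more than one place, so the gap cannot be assigned to any single change, and no step between measured compounds is available.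

The step followed here runs from compound 1 to compound 3 `CCNc1nccc(N2CC[C@H](NC(=O)Nc3ccc(Cl)c(C(F)(F)F)c3)C2)n1`. The change is ethyl in place of hydrogen on a nitrogen on an aromatic ring: the amino on the core of compound 1 becomes ethylamino, with nothing else altered. Nothing measured in this series isolates this change. The aryl urea of compound 1 is kept, so the number for compound 3 is expected to stay near that of compound 1, with a modest move toward a higher number more likely than a lower one. The expected step is a 2.8-fold higher number from compound 1 to compound 3 (0.45 log units; beyond the scatter). For compound 3 in this assay the estimate is 120 nM, with a range from 40 nM to 400 nM.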

Compound 3, half-maximal inhibitory concentration in the CDK8/Cyclin C assay: 8.9 nM
Estimate against measurement, compound 3: 13-fold (1.13 log units) above; the whole stated range lies above it.
By their numbers in the CDK8/Cyclin C assay, from the lowest: compound 3; then compound 1; then compound 2.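

Within the data shown here, in the CDK8/Cyclin C assay, ethyl in place of hydrogen on a nitrogen on an aromatic ring gives a 4.8-fold lower number from compound 1 to compound 3 (0.68 log units; beyond the scatter), the first step that isolates this position, and it shows that the amino on the core of compound 1 can carry an ethyl group without any loss in this read-out. In a physicochemical assay for solubility, measured as kinetic solubility (on this read-out lower numbers stand for lower solubility and higher numbers for higher solubility), compound 1 gives 30300 nM and compound 3 gives 29900 nM, two numbers within the usual scatter of each other, so this change leaves the solubility read-out without a measurable step even as the inhibitor number falls. Nothing available on these compounds gives a reason for the lower number of compound 3.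

Going by these compounds, it remains open whether a longer chain such as propyl, or a chain ending in a hydroxyl group such as 2-hydroxyethyl, on the same nitrogen would extend this step or reverse it. Compound 2 carries methylamino but also a different aryl urea, so the part of its higher number that belongs to the methylamino group cannot be separated from the part that belongs to the aryl urea.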